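The source may report more compounds than this note shows. Statements on the series, on what has been measured and on what is new or still open speak of the compounds shown alone.

Compound 1 `CCCCCC(CCO)n1cnc2c(OC)ncnc21`, compound 2 `CCCCCC(CCO)n1cnc2c(NC)ncnc21` and compound 3 `CCCCCC(CCO)n1cnc2cncnc21` share one core and differ only in the group on an aromatic carbon: methoxy, methylamino or hydrogen. In a functional assay on HCT-116 cells (Homo sapiens) for antiproliferative activity, read by MTT assay, with a stated time of 48 h (on this read-out higher numbers stand for weaker inhibition and lower numbers for stronger inhibition), compound 2 gives > 50000 nM, which is a limit of the assay and not a number. Compound 1 also gives only a limit, > 50000 nM. Compound 3 likewise gives only a limit, > 50000 nM. Compound 2 thus stands with the others at the limit of > 50000 nM in this assay, at which 3 of the 3 values shown sit. The measured steps offer no size to work from: there is a step that the two limits leave unreadable from compound 1 to compound 2, a step that the two limits leave unreadable from compound 1 to compound 3 and a step that the two limits leave unreadable from compound 2 to compound 3. All of them concern the aromatic carbon, and none touches the chain.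

Compound 4 `CCCCCCCCCCC(CCO)n1cnc2c(NC)ncnc21` keeps the methylamino group and changes the chain instead: pentyl in place of hydrogen on a saturated chain carbon, six bonds along the chain from an aromatic nitrogen. The data give no measured guide to this change in this assay, so only a cautious expectation is possible, and the reading may well stay at the limit. The expected at least 1.6-fold lower number from compound 2 to compound 4 (0.22 log units; that floor lies within the scatter) is a modest move toward stronger inhibition. For compound 4 the estimated value is 30000 nM, with an expected range of 8000 nM to 70000 nM.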

Compound 4, half-maximal inhibitory concentration: 12700 nM
Compound 4: middle estimate off by 2.4-fold (0.37 log units), on the high side; measured number inside the range.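

Among the compounds shown here, the earlier steps, all on the aromatic carbon, could not be read, so this is the first change with a readable size: in this assay, pentyl in place of hydrogen on a saturated chain carbon, six bonds along the chain from an aromatic nitrogen, gives an at least 3.9-fold lower number from compound 2 to compound 4 (0.59 log units; beyond the scatter). The chain position therefore responds in this read-out, while the changes on the aromatic carbon left every value at a limit of the assay. Compound 4 is the only compound shown that gives a number rather than a limit: the limit of > 50000 nM in this assay, at which 3 of the 4 values shown sit.

As far as these compounds go, whether a shorter group such as propyl or a longer one such as octyl, or a carboxylic acid, at this place would move the number further remains open. Also open, from the compounds shown here alone, is whether methoxy or hydrogen in place of methylamino would change the number with the pentyl group present.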